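Swapping an amidoxime-bearing ring for a trimethoxyphenyl group

The source may hold more compounds than are shown below. What is called first, only, known or untested is meant among the compounds shown, and "the series" means these compounds.

Measured compounds:
- compound 1, `CC1(c2ccc(-c3ccc(/C(N)=N\O)cc3)cc2)CC(S(=O)(=O)c2ccc(F)cc2)=C(c2ccc(/C(N)=N\O)cc2)O1`: 3940 nM
- compound 2, `CC1(Cc2ccccc2)CC(S(=O)(=O)c2ccc(F)cc2F)=C(c2ccc(/C(N)=N\O)cc2)O1`: 41500 nM
- compound 3, `COc1ccc(C2(c3ccccc3)CC(S(=O)(=O)c3ccc(F)cc3)=C(c3ccc(/C(N)=N\O)cc3)O2)cc1`: 11300 nM

All three were tested in an ADME assay on J774.A1 cells (Mus musculus) for cytotoxicity, read by MTT assay, with a stated time of 72 h; a higher number here means that more compound is tolerated, a lower number that less compound is tolerated. Compound 1 gives 3940 nM, the lowest of the three numbers, so it is the least tolerated compound here; compound 3 and compound 2 both lie beyond the usual scatter above it. Compound 1 carries two amidoxime groups on its core, whereas compound 2 and compound 3 carry only one.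

Compound 4, `COc1cc(-c2ccc(C3(C)CC(S(=O)(=O)c4ccc(F)cc4)=C(c4ccc(/C(N)=N\O)cc4)O3)cc2)cc(OC)c1OC`, has not yet been measured. It differs from compound 1 by a group of 12 heavy atoms (9 carbon, 3 oxygen; one six-membered aromatic ring of carbon only) in place of a group of 10 heavy atoms (7 carbon, 2 nitrogen, 1 oxygen; one six-membered aromatic ring of carbon only), on an aromatic carbon. Among the compounds with values here, with that change, compound 4 also keeps only one amidoxime group, which it shares with compound 2 and compound 3. Since compound 2 gives 41500 nM and compound 3 gives 11300 nM, a step upward in this assay beyond the scatter seems likely, though the size is uncertain because compound 2 and compound 3 themselves sit far apart. Compound 4 is therefore expected to be tolerated somewhat better than compound 1, with an estimated step of a 2.5-fold higher number from compound 1 to compound 4 (0.40 log units; beyond the scatter). The estimated value for compound 4 is 10000 nM, within a range from 3500 nM to 30000 nM.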

Compound 4, half-maximal cytotoxic concentration: 5220 nM
Compound 4: the middle estimate sits 1.9-fold (0.28 log units) above what was measured, within the range that was stated.
By their numbers in this assay, from the lowest: compounds 1 and 4 (each within the scatter of the next); then compound 3; then compound 2.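

In this assay, putting a 3,4,5-trimethoxyphenyl group in place of the amidoxime-bearing ring, on an aromatic carbon para to a large group, gives a 1.3-fold higher number from compound 1 to compound 4 (0.12 log units; within the scatter), which leaves the two compounds indistinguishable. The earlier compounds shown here differ from one another in several places, so they could not isolate this exchange; this pair shows that, on this core and at this position, losing the second amidoxime group makes no readable difference to how well the cells tolerate the compound. Nothing available explains why these two groups read alike.

As far as these compounds go, it remains open whether a plain phenyl ring, or a ring carrying an amine or a carboxylic acid, would read the same at this position. From the compounds shown here alone, whether this exchange would behave alike on a different core also remains open.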